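The compounds below may be only part of what the source reports. "The series", "measured", "known", "first", "only" and "open" are said of these compounds alone.

In a functional assay on a cell-free system (plasma, Homo sapiens), with a stated time of 3 min (a higher number here means a weaker inhibitor, a lower number a stronger inhibitor), compound 1 (`O=C(NCc1cc(Cl)ccc1-n1cnnn1)[C@@H]1C[C@@H]2C[C@@H]2N1C(=O)[C@H](O)CC1CC1`) gives 1700 nM and compound 3 (`CC(C)(C)[C@@H](O)C(=O)N1OCC[C@H]1C(=O)NCc1cc(Cl)ccc1-n1cnnn1`) gives 1600 nM while compound 2 (`CC1(C[C@@H](O)C(=O)N2N=CC[C@H]2C(=O)NCc2cc(Cl)ccc2-n2cnnn2)CC1`) gives 730 nM as the lowest number of the three, clearly apart from both others. Compound 4 (`CC(C)CC[C@@H](O)C(=O)N1N=CC[C@H]1C(=O)NCc1cc(Cl)ccc1-n1cnnn1`) differs from compound 2 in one place, with isobutyl in place of 1-methylcyclopropyl on a saturated chain carbon, two bonds along the chain from a carbonyl carbon and an oxygen on a saturated carbon. Within the data shown here, no measured pair shows this change alone. Compound 2 at 730 nM sits lowest of the set, so a small rise in the number in this assay is expected, perhaps none beyond the usual scatter. The estimated step is a 1.4-fold higher number from compound 2 to compound 4 (0.14 log units; within the scatter) and counts as modest. For compound 4 the expected value is 1000 nM (range 350 nM to 2800 nM).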

Compound 4, half-maximal inhibitory concentration: 630 nM
Beside the measured number, compound 4's estimate is 1.6-fold (0.20 log units) above it; the range from low to high includes it.
By their numbers in this assay, from the lowest: compounds 4 and 2 (each within the scatter of the next); then compounds 3 and 1 (each within the scatter of the next).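

Placing isobutyl where 1-methylcyclopropyl stood gives a 1.2-fold lower number from compound 2 to compound 4 (0.06 log units; within the scatter) in this assay and so no real change. At this saturated chain carbon, then, the three-membered ring of carbon can give way to an open branched group with the same 4 heavy atoms and the number holds, at least for this one pair. Nothing available explains why the two groups read alike. Still open, as far as these compounds go, is whether a longer chain, an amine or a carboxylic acid at this carbon would also leave the number unchanged.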